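Swapping a pyrimidinyl for a methoxyphenyl on the core

The compounds below may be only part of what the source reports. "The series", "measured", "known", "first", "only" and "open" are said of these compounds alone.

Measured compounds:
- Compound 1 `CC(C)c1nn(-c2ccc(C(N)=O)c(N[C@H]3CC[C@H](O)CC3)c2)c2nccc(-n3cnc(-c4ccncc4)c3)c12`: 165 nM
- Compound 2 `CC(C)c1nn(-c2ccc(C(N)=O)c(N[C@H]3CC[C@H](O)CC3)c2)c2nccc(-n3cnc(-c4ccc(Oc5ccccc5)cc4)c3)c12`: 503 nM
- Compound 3 `CC(C)c1nn(-c2ccc(C(N)=O)c(N[C@H]3CC[C@H](O)CC3)c2)c2nccc(-n3cnc(-c4cncnc4)c3)c12`: 387 nM

In a functional assay on SK-BR-3 cells (Homo sapiens) for inhibition, read by CellTiter-Glo, with a stated time of 72 h (a higher number here means a weaker inhibitor, a lower number a stronger inhibitor), compound 3 gives 387 nM, the second highest of the three numbers; its value sits within the scatter of compound 2 and is separated from compound 1 by a 2.3-fold higher number from compound 1 to compound 3 (0.37 log units; beyond the scatter). Compound 4 `COc1ccc(-c2cn(-c3ccnc4c3c(C(C)C)nn4-c3ccc(C(N)=O)c(N[C@H]4CC[C@H](O)CC4)c3)cn2)cc1` differs from compound 3 by 4-methoxyphenyl in place of pyrimidin-5-yl on an aromatic carbon. For the measured compounds named here, no measured step covers exactly this exchange. Going by the values given here, the only step that bears on it, a 2.3-fold higher number from compound 1 to compound 3 (0.37 log units; beyond the scatter), shows a modest shift when one six-membered ring with ring nitrogens replaces another. Compound 2, which also carries a carbon-only aromatic ring bearing an oxygen, gives 503 nM, close to compound 3. The expected step of a 1.0-fold higher number from compound 3 to compound 4 (0.01 log units; within the scatter) is therefore small, within the scatter. Compound 4 is estimated at 400 nM, likely between 150 nM and 1100 nM.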

Compound 4, half-maximal inhibitory concentration: 256 nM
Beside the measured number, compound 4's estimate is 1.6-fold (0.19 log units) above it; the measured number falls inside the stated range.
By their numbers in this assay, from the lowest: compounds 1, 4, 3 and 2 (each within the scatter of the next, the first and the last beyond it).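

A carbon-only ring carrying an oxygen, 4-methoxyphenyl, can sit on this aromatic carbon in this assay with no step beyond the scatter from either nitrogen-containing ring (a 1.5-fold lower number from compound 3 to compound 4 (0.18 log units; within the scatter); a 1.6-fold higher number from compound 1 to compound 4 (0.19 log units; within the scatter)). Methyl in place of phenyl on that oxygen also stays within the scatter (a 2.0-fold lower number from compound 2 to compound 4 (0.29 log units; within the scatter)), so ring nitrogens are not needed for activity in this range among these compounds. Nothing available explains these small steps. Still open, as far as these compounds go, is how an amine or a carboxylic acid on this ring would read, and whether the ring itself is needed, which a longer chain in its place could test.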